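The source may report more compounds than this note shows. Statements on the series, on what has been measured and on what is new or still open speak of the compounds shown alone.

In a functional assay on A549 cells (Homo sapiens) for inhibition, read by MTT assay, with a stated time of 72 h (a higher number here means a weaker inhibitor, a lower number a stronger inhibitor), compound 1 `Nc1ccccc1NC(=O)c1ccc(CNC(=O)/C=C/c2cnc3ccccn23)cc1` gives 832 nM and compound 2 `Nc1ccccc1NC(=O)c1ccc(CNC(=O)/C=C/c2cnc3cccnn23)cc1` gives 723 nM. Among the compounds with values here, these two values lie within the usual scatter of each other, so compound 2 stands level with compound 1 on the only numbers available. Compound 3 `Cc1nc2ccccn2c1/C=C/C(=O)NCc1ccc(C(=O)Nc2ccccc2N)cc1` has not yet been measured. Its structure differs from that of compound 2 by one change: a group of 10 heavy atoms (8 carbon, 2 nitrogen; one five-membered aromatic ring with 2 hetero atoms, one six-membered aromatic ring with 1 hetero atom) in place of a group of 9 heavy atoms (6 carbon, 3 nitrogen; one five-membered aromatic ring with 2 hetero atoms, one six-membered aromatic ring with 2 hetero atoms), on a double-bonded chain carbon bound to a double-bonded chain carbon. Within the data shown here, the only measured step that bears on this change is a 1.2-fold lower number from compound 1 to compound 2 (0.06 log units; within the scatter). It also exchanged one two-ring group for another at the same place, and it stayed within the scatter. Among the measured compounds shown here, no measured compound carries the group that enters here, so the data give no sign of a larger shift in this assay and no direction can be argued. The expected step, a 1.1-fold higher number from compound 2 to compound 3 (0.03 log units; within the scatter), is therefore none beyond the scatter. For compound 3 the estimate is 780 nM, with an expected range from 350 nM to 1700 nM.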

Compound 3, half-maximal inhibitory concentration: 1310 nM
Beside the measured number, compound 3's estimate is 1.7-fold (0.23 log units) below it; the range from low to high includes it.
By their numbers in this assay, from the lowest: compounds 2, 1 and 3 (each within the scatter of the next).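

In this assay, methyl in place of hydrogen on an aromatic carbon gives a 1.6-fold higher number from compound 1 to compound 3 (0.20 log units; within the scatter), and the exchange of the two-ring groups gives a 1.8-fold higher number from compound 2 to compound 3 (0.26 log units; within the scatter), both printed as within the scatter. On a double-bonded chain carbon bound to a double-bonded chain carbon, the three two-ring groups shown, one of them bearing a methyl, therefore stand level, and this first substituent on the aromatic carbon gives no shift that can be told apart from repeat-to-repeat variation. No evidence is available that would explain these numbers. From the compounds shown here alone, whether an amine, a carboxylic acid or a longer chain in place of the methyl would give a step beyond the scatter remains open. So does the outcome of a phenyl group on that same aromatic carbon.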